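The source may hold more compounds than are shown below. What is called first, only, known or untested is meant among the compounds shown, and "the series" means these compounds.

Measured so far:
compound 1, `N[C@H]1CC[C@H](Nc2c(C(=O)NCc3ccc(Oc4ccccc4)cc3)nc(Br)c3cccnc23)CC1`, 9000 nM
compound 2, `COc1ccc(CNC(=O)c2nc(Br)c3cccnc3c2N[C@H]2CC[C@H](N)CC2)cc1`, 4000 nM

Both were tested in a functional assay on HEY cells (Homo sapiens) for cytotoxicity, read by MTT assay, with a stated time of 72 h; a lower number here means a stronger inhibitor, a higher number a weaker inhibitor. Among the compounds with values here, compound 2 gives the lowest of the two numbers; the one step known, a 2.3-fold lower number from compound 1 to compound 2 (0.35 log units; beyond the scatter), was a modest change in the group on the oxygen at the far end of the amide side chain. Compound 3, `C[C@H](NC(=O)c1nc(Br)c2cccnc2c1N[C@H]1CC[C@H](N)CC1)c1ccc(F)cc1`, is not yet measured. It differs from compound 2 in one place: 1-(4-fluorophenyl)ethyl in place of 4-methoxybenzyl on an amide-type nitrogen. Within the data shown here, the only measured step alters the same outer aryl group, but not in this way, so it gives little to build on. With no firm guide, a step within the scatter is expected, a 1.3-fold higher number from compound 2 to compound 3 (0.10 log units; within the scatter), and compound 3 is estimated at 5000 nM, within 1500 nM to 15000 nM.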

Compound 3, half-maximal inhibitory concentration: > 10000 nM
Compound 3: only a limit was reported; the forecaster's own chance of this, stated with the estimate: 10%; middle value at least 2.0-fold (0.30 log units) away from the limit.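

In this assay, the swap on the amide-type nitrogen gives an at least 2.5-fold higher number from compound 2 to compound 3 (0.39 log units; beyond the scatter), so the number here responds to this change in the amide side chain and does not stay within the scatter. The result for compound 3 is a limit and not a number: the limit of > 10000 nM in this assay, at which 1 of the 3 values shown sits.

The swap replaces the methoxy group with fluorine and adds a defined stereocentre at once, and the compounds shown cannot separate these two changes. Also open, going by these compounds, is whether a longer chain or a carboxylic acid on this nitrogen's side chain would lower the number.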